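A few compounds are considered here, and "the series" means these few. Any claim that something is new, unique, unknown or untested is made for them only; others in the source may bear on it.

Going by the values given here, compound 1 `COc1ccccc1C(=O)NC(=O)Nc1ccc(-c2ccccc2)c(C(F)(F)F)c1` is one of two compounds measured in a physicochemical assay for solubility, in simulated intestinal fluid (on this read-out lower numbers stand for lower solubility and higher numbers for higher solubility), where compound 1 gives 23 ug/mL. Among the compounds with values here, its only measured neighbour is compound 2 `COc1ccccc1C(=O)NC(=O)Nc1ccc(-c2ccccc2)c(C(C)C)c1`, which in this assay gives 24 ug/mL; the change from compound 1 to compound 2, isopropyl in place of trifluoromethyl on an aromatic carbon, gives a 1.0-fold higher number from compound 1 to compound 2 (0.02 log units; within the scatter), so the two numbers sit within the scatter of each other and neither can be ranked against the other.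

Compound 3 `COc1ccccc1C(=O)NC(=O)Nc1ccc(-c2nccs2)c(C(F)(F)F)c1` has not yet been measured in this assay. It differs from compound 1 as follows: 1,3-thiazol-2-yl in place of phenyl on an aromatic carbon. Within the data shown here, no measured step covers this exchange; the single step available, a 1.0-fold higher number from compound 1 to compound 2 (0.02 log units; within the scatter), alters the trifluoromethyl group, which in compound 3 stays in place, and so it offers no direct guide. Among the measured compounds shown here, the only anchor is compound 1, whose value 23 ug/mL sets the starting point. The expectation for compound 3 is therefore a step of a 1.7-fold higher number from compound 1 to compound 3 (0.24 log units; within the scatter), which may well fall inside the scatter. Compound 3 is estimated at 40 ug/mL in this assay, with a range from 15 ug/mL to 110 ug/mL.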

Compound 3, solubility: 12 ug/mL
Compound 3: the middle estimate sits 3.3-fold (0.52 log units) above what was measured, outside the stated range (below it).
By their numbers in this assay, from the lowest: compounds 3, 1 and 2 (each within the scatter of the next).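

With compound 3 the measured series reaches a second place on the molecule: the aromatic carbon ortho to a trifluoromethyl group and para to a large group, which the earlier step left untouched. In this assay, 1,3-thiazol-2-yl in place of phenyl at this carbon gives a 1.9-fold lower number from compound 1 to compound 3 (0.28 log units; within the scatter), so the two compounds cannot be ranked, even though the exchange swaps a six-membered aromatic ring of carbon only for a five-membered aromatic ring with 2 hetero atoms, and 0 hydrogen-bond acceptors for 2. The data give no measured property that could explain where these numbers fall, and the result therefore stands as an observation only.

On these data alone, what remains open is whether this place tolerates other kinds of group just as quietly, such as a phenyl ring carrying an amine or a carboxylic acid, or a pyridine ring in place of the 1,3-thiazol-2-yl. It is also open whether the exchange of phenyl for 1,3-thiazol-2-yl would give a similar step with isopropyl rather than trifluoromethyl on the neighbouring position of the ring, since the compounds shown do not pair those two changes.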